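From compound 3 to compound 4: shifting the carbamoylphenyl group

A few compounds are considered here, and "the series" means these few. Any claim that something is new, unique, unknown or untested is made for them only; others in the source may bear on it.

Compound 1 `CC(C)Oc1ccc(C(O)(c2ccc(C(F)(F)F)cc2)c2cccnc2)cc1` reads 47600 nM
Compound 2 `N#Cc1ccc(C(O)(c2ccc(C(F)(F)F)cc2)c2cccnc2)cc1` reads 76500 nM
Compound 3 `NC(=O)c1cccc(C(O)(c2ccc(C(F)(F)F)cc2)c2cccnc2)c1` reads > 100000 nM (a limit, not a number)

All three values come from an ADME assay on L6 cells (Rattus norvegicus) for cytotoxicity, read by resazurin assay, with a stated time of 72 h (on this read-out higher numbers stand for weaker inhibition and lower numbers for stronger inhibition), and the compounds share one core. Compound 3 stands at the limit of > 100000 nM in this assay, at which 1 of the 3 values shown sits, and has no number of its own.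

The change to compound 4 `NC(=O)c1ccc(C(O)(c2ccc(C(F)(F)F)cc2)c2cccnc2)cc1` is 4-carbamoylphenyl in place of 3-carbamoylphenyl on a saturated chain carbon bound to two aromatic carbons and an oxygen on a saturated carbon and the same atoms are joined differently: 4-carbamoylphenyl takes the place of 3-carbamoylphenyl on the saturated chain carbon bound to two aromatic carbons and an oxygen on a saturated carbon.

Two measured steps offer guidance, though neither is this same exchange. The first is a 1.6-fold higher number from compound 1 to compound 2 (0.21 log units; within the scatter) and the second is an at least 1.3-fold higher number from compound 2 to compound 3 (0.11 log units; that floor lies within the scatter) so neither shows a change beyond the usual scatter. On that basis, no step beyond the scatter is expected in this assay in either direction. The expected step is an at least 1.1-fold lower number from compound 3 to compound 4 (0.04 log units; that floor lies within the scatter) and this is only an estimate, since compound 3 offers a limit to start from. Compound 4 is estimated at 90000 nM in a range from 50000 nM to 160000 nM and may well report only a limit again.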

Compound 4, half-maximal inhibitory concentration: > 100000 nM
Compound 4 gave a limit, no number; the forecaster's own chance of this, stated with the estimate: 45%; middle value at least 1.1-fold (0.04 log units) from the limit.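

In this assay compound 4 gives > 100000 nM, which is a limit and not a number. Moving the carbamoyl group, in 4-carbamoylphenyl in place of 3-carbamoylphenyl, therefore leaves a step that cannot be read, and the shift of position can be said only to leave both compounds at the same ceiling: the limit of > 100000 nM in this assay, at which 2 of the 4 values shown sit. Compound 4 nevertheless adds something the earlier steps did not show, since replacing the isopropoxy group with the carbamoyl group gives an at least 2.1-fold higher number from compound 1 to compound 4 (0.32 log units; beyond the scatter), the first listed step to clear the scatter, towards weaker inhibition, whereas carbamoyl in place of cyano on an aromatic carbon gives only an at least 1.3-fold higher number from compound 2 to compound 4 (0.11 log units; that floor lies within the scatter), so the nitrile and the carbamoyl group remain unseparated.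

The compounds shown leave open whether 3-carbamoylphenyl and 4-carbamoylphenyl differ at all on this read-out, as neither has a number of its own. They also leave open whether an amine or a carboxylic acid on that aromatic carbon would stay at the limit or return a readable value.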